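The compounds below may be only part of what the source reports. "The series", "measured", "known", "first", "only" and "open" are said of these compounds alone.

Measured so far in an ADME assay on J774.A1 cells (Mus musculus) for cytotoxicity, read by MTT assay, with a stated time of 72 h; on this read-out higher numbers stand for lower toxicity in this test and lower numbers for higher toxicity in this test:
compound 1 `Clc1cccc(COC(CCn2cncn2)c2ccco2)c1` gives 18600 nM
compound 2 `Clc1ccc(COC(CCn2ccnc2)c2ccco2)c(Cl)c1` gives 56200 nM

Compound 1 stands at the lowest of the two numbers in this assay; the nearest, compound 2, shows a higher number, and the gap between the two lies beyond the scatter. Compound 2 differs from compound 1 in more than one place, so its value alone says nothing about any single change. The next compound, compound 3 `Clc1cccc(COC(CCn2ccnc2)c2ccco2)c1`, has not yet been measured in this assay. It differs from compound 1 as follows: 1H-imidazol-1-yl in place of 1H-1,2,4-triazol-1-yl on a saturated chain carbon, three bonds along the chain from an aromatic carbon and an oxygen on a saturated carbon. Going by the values given here, no measured pair isolates this change, so the size of the step is open. The expectation for compound 3 in this assay is a small step, if any, toward a higher number, about the size of the scatter: a 1.3-fold higher number from compound 1 to compound 3 (0.13 log units; within the scatter). Compound 3 is accordingly estimated at 25000 nM, with a range from 10000 nM to 60000 nM.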

Compound 3, half-maximal cytotoxic concentration: 60200 nM
The estimate for compound 3 lay 2.4-fold (0.38 log units) below the measured number; measured number outside the range, above it.
By their numbers in this assay, from the lowest: compound 1; then compounds 2 and 3 (each within the scatter of the next).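

In this assay, going by these compounds alone, 1H-imidazol-1-yl in place of 1H-1,2,4-triazol-1-yl gives a 3.2-fold higher number from compound 1 to compound 3 (0.51 log units; beyond the scatter), the first single change that can be read on its own. This place on the saturated chain carbon therefore matters on this read-out: exchanging one five-membered aromatic ring for the other, with the rest of the core of compound 1 untouched, moves the number modestly toward lower toxicity in this test. No measurement at hand explains the step.

Going by these compounds, the step rests on one pair, so whether it carries over to other substitution on the rest of the core remains open. On these data alone, how an amine or a 1H-tetrazol-1-yl ring at this place would read, or a longer chain carrying the 1H-imidazol-1-yl group, is also open.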